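The source may hold more compounds than are shown below. What is called first, only, known or untested is meant among the compounds shown, and "the series" means these compounds.

Three compounds have numbers in an assay on cells for inhibition of Voltage-dependent T-type calcium channel subunit alpha-1G (Homo sapiens), read by patch clamp; a lower number here means a stronger inhibitor, a higher number a weaker inhibitor:
compound 1 `CN(C)CCCCCSC1=Nc2ccccc2C(CC(=O)NCc2ccccc2)N1c1ccc(-c2ccccc2)cc1`, 7770 nM;
compound 2 `O=C(CC1c2ccccc2N=C(SCCCCCN2CCCC2)N1c1ccccc1)NCc1ccc(F)cc1`, 13500 nM;
compound 3 `CN(C)CCCCCSC1=Nc2ccccc2C(CC(=O)NCc2ccc(F)cc2)N1c1ccc(-c2ccccc2)cc1`, 27400 nM.

Compound 3 has the highest number of the three and is thus the weakest inhibitor here; compound 2 stands nearest, compound 1 furthest. Compound 4 `CN(C)CCCCCSC1=Nc2ccccc2C(CC(=O)NCc2ccc(F)cc2)N1c1ccccc1` differs from compound 3 by hydrogen in place of phenyl on an aromatic carbon. Going by the values given here, no measured step shows this change directly. Among the compounds with values here, the only single-point step, a 3.5-fold higher number from compound 1 to compound 3 (0.55 log units; beyond the scatter), concerns a fluoro and not this ring. Compound 2 carries a plain phenyl like compound 4 but also a different amine, and its number is lower than that of compound 3; those two values are the closest guide. Compound 4 is therefore expected to sit near the number of compound 2. For compound 4 the expected step is a 2.3-fold lower number from compound 3 to compound 4 (0.36 log units; beyond the scatter). The estimate for compound 4 is 12000 nM, within 5000 nM to 30000 nM.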

Compound 4, half-maximal inhibitory concentration: 555000 nM
Beside the measured number, compound 4's estimate is 46-fold (1.67 log units) below it; measured number outside the range, above it.
By their numbers in this assay, from the lowest: compounds 1 and 2 (each within the scatter of the next); then compound 3; then compound 4.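

Going from 4-phenylphenyl to phenyl gives a 20-fold higher number from compound 3 to compound 4 (1.31 log units; beyond the scatter), so the outer ring at this position has a large effect on the number, which no earlier step could show. With phenyl in place, dimethylamino instead of pyrrolidin-1-yl gives a 41-fold higher number from compound 2 to compound 4 (1.61 log units; beyond the scatter), so the amine at the chain end matters strongly as well. Nothing available explains either step. Still open, as far as these compounds go, is whether a smaller group on that aromatic carbon, such as methoxy or a chlorine atom, keeps part of the outer ring's effect. Also open, from the compounds shown here alone, is whether piperidine at the chain end would behave like pyrrolidine.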